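Nitrofuran and nitrothiophene enones: THP-1 cytotoxicity notes

The compounds below may be only part of what the source reports. "The series", "measured", "known", "first", "only" and "open" are said of these compounds alone.

Compound 2 `O=C(/C=C/c1ccc([N+](=O)[O-])o1)c1ccc(-n2ccnc2)cc1` and compound 3 `O=C(/C=C/c1ccc([N+](=O)[O-])s1)c1ccc(-n2ccnc2)cc1` both carry the 1H-imidazol-1-yl group; the difference between their two cores is not broken down here. In an ADME assay on THP-1 cells (Homo sapiens) for cytotoxicity, read by resazurin assay, with a stated time of 72 h (on this read-out lower numbers stand for higher toxicity in this test and higher numbers for lower toxicity in this test), compound 2 gives 22200 nM. In this assay compound 3 gives 23400 nM, within the scatter of compound 2, so no order is read between them. Compound 1 `CC(C)(C)c1ccc(C(=O)/C=C/c2ccc([N+](=O)[O-])o2)cc1` differs from compound 2 by tert-butyl in place of 1H-imidazol-1-yl on an aromatic carbon. For compound 1 this assay reports only a limit and no number, > 50000 nM. That value is the limit of > 50000 nM in this assay, at which 1 of the 3 values shown sits, so the step of an at least 2.2-fold higher number from compound 2 to compound 1 (0.35 log units; beyond the scatter) is itself a lower bound.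

Compound 4 `CC(C)(C)c1ccc(C(=O)/C=C/c2ccc([N+](=O)[O-])s2)cc1` is not yet measured; it differs from compound 3 by tert-butyl in place of 1H-imidazol-1-yl on an aromatic carbon, the same change at the same place, made on the core of compound 3 instead. Because of an at least 2.2-fold higher number from compound 2 to compound 1 (0.35 log units; beyond the scatter) a step of comparable size is expected, a 2.6-fold higher number from compound 3 to compound 4 (0.41 log units; beyond the scatter), with a fair chance that this assay again returns only a limit. The expected value for compound 4 in this assay is 60000 nM, with a plausible range from 30000 nM to 150000 nM.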

Compound 4, half-maximal cytotoxic concentration: 8400 nM
Compound 4: middle estimate off by 7.1-fold (0.85 log units), on the high side; the measured number lies below the stated range.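

In this assay, putting tert-butyl in place of 1H-imidazol-1-yl on the core of compound 3 gives a 2.8-fold lower number from compound 3 to compound 4 (0.44 log units; beyond the scatter), so the same change does not carry over from one core to the other with the same direction: the same change on two cores in this assay, an at least 2.2-fold higher number (0.35 log units; beyond the scatter) from compound 2 to compound 1 and a 2.8-fold lower number (0.44 log units; beyond the scatter) from compound 3 to compound 4, at least 6.2-fold (0.79 log units) apart, beyond the scatter of two such steps. Compound 1 gives only a limit and not a number, so the gap between the two steps is itself a lower bound: the limit of > 50000 nM in this assay, at which 1 of the 4 values shown sits. With a single pair on each core, this shows that the change cannot be treated as a fixed step in this series, but it does not show what makes the two cores part.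

The compounds shown leave open whether other groups at this place on the six-membered aromatic ring, such as a dimethylamino group, a carboxylic acid or a longer alkyl chain, would follow the pair on the core of compound 2 or the pair on the core of compound 3. Also open, as far as these compounds go, is whether the split holds for any change other than this one.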